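The source may report more compounds than this note shows. Statements on the series, on what has been measured and on what is new or still open speak of the compounds shown alone.

Measured so far in an assay on SK-N-MC cells for inhibition of Neuropeptide Y receptor type 1 (Homo sapiens); a higher number here means a weaker inhibitor, a lower number a stronger inhibitor:
compound 1, `COC(=O)C1=C(C)N=C(C)/C(=C(/O)OC)C1c1cccc(N/C(=N/CCNC2CCN(c3ccccc3O)CC2)NC#N)c1`, gives 5 nM.
compound 2, `COC(=O)C1=C(C)N=C(C)/C(=C(/O)OC)C1c1cccc(NC(=O)NCCNC2CCN(c3ccccc3C(F)(F)F)CC2)c1`, gives 31 nM.

Compound 2 stands with the higher of these two numbers; compound 1 is the nearest, and its number is lower by a margin beyond the usual scatter. The two compounds differ in more than one place, so the gap between them cannot be traced to any single exchange.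

Compound 3, `COC(=O)C1=C(C)N=C(C)/C(=C(/O)OC)C1c1cccc(NC(=O)NCCNC2CCN(c3ccccc3SC)CC2)c1`, has not yet been measured. It differs from compound 2 in one place: methylsulfanyl in place of trifluoromethyl on an aromatic carbon. No pair of measured compounds differs by this exchange alone, so there is no shown step to lean on. Without such a step, the expected change is a 1.0-fold lower number from compound 2 to compound 3 (0.01 log units; within the scatter), a step expected to stay within the scatter in either direction. Compound 3 is therefore estimated at 30 nM in this assay, with an expected range from 10 nM to 100 nM.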

Compound 3, half-maximal inhibitory concentration: 5 nM
Compound 3: the middle estimate sits 6.0-fold (0.78 log units) above what was measured; the measured number lies below the stated range.
By their numbers in this assay, from the lowest: compounds 1 and 3 (each within the scatter of the next); then compound 2.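

In this assay methylsulfanyl in place of trifluoromethyl brings a 6.2-fold lower number from compound 2 to compound 3 (0.79 log units; beyond the scatter) and forms the first single exchange shown, so the group on this aromatic carbon, ortho to a large group, clearly moves the number. The exchange swaps a group of four heavy atoms for one of two and adds one hydrogen-bond acceptor, but this single step cannot separate these differences or show whether either one matters. Nothing measured here gives a reason for the step.

Open, going by these compounds, is whether other groups on this aromatic carbon, such as methoxy, ethylsulfanyl or a single chlorine atom, would give a number like that of compound 3. Also open, on these data alone, is whether the same exchange would bring a similar step in a compound with the different chain of compound 1.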